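A cinnamamide extension of a weak antiproliferative amide

The compounds below may be only part of what the source reports. "The series", "measured", "known", "first", "only" and "open" are said of these compounds alone.

Three amides built on a shared core have been tested in a functional assay on HCT-116 cells (Homo sapiens) for antiproliferative activity, read by MTT assay, with a stated time of 48 h; a higher number here means a weaker inhibitor, a lower number a stronger inhibitor. Compound 1 `O=C(Nc1cc(Sc2ncn[nH]2)c(O)c2ccccc12)c1cccc([N+](=O)[O-])c1` gives 70200 nM in this assay. Compound 3 `O=C(Nc1cc(Sc2ncn[nH]2)c(O)c2ccccc12)c1ccc(Cl)cc1` gives 43300 nM in this assay. Compound 2 `O=C(Nc1cc(Sc2ncn[nH]2)c(O)c2ccccc12)c1cccc(Cl)c1` gives only a limit of the assay in this assay, > 100000 nM, and sits at the limit of > 100000 nM in this assay, at which 1 of the 3 values shown sits. Among the two numbers shown, compound 3 has the lowest, yet the gap to compound 1 is small: a 1.6-fold lower number from compound 1 to compound 3 (0.21 log units; within the scatter). The move from the 3-substituted to the 4-substituted ring gives a clearer effect: an at least 2.3-fold lower number from compound 2 to compound 3 (0.36 log units; beyond the scatter). Swapping the nitro for chloro gives an at least 1.4-fold higher number from compound 1 to compound 2 (0.15 log units; that floor lies within the scatter).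

Compound 4 `O=C(/C=C/c1ccc(Cl)cc1)Nc1cc(Sc2ncn[nH]2)c(O)c2ccccc12` arises from compound 3 by 2-(4-chlorophenyl)ethenyl in place of 4-chlorophenyl on a carbonyl carbon. Going by the values given here, none of the measured steps concerns such a change; they all swap or move a group on the ring while keeping the ring directly on the carbonyl carbon, so no direct guide exists. Since the same 4-chlorophenyl group stays, and compound 3 gives 43300 nM, the expected step is small, a 1.2-fold lower number from compound 3 to compound 4 (0.09 log units; within the scatter), in no direction beyond the scatter. Compound 4 is therefore estimated at 35000 nM, in a range from 12000 nM to 100000 nM.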

Compound 4, half-maximal inhibitory concentration: > 100000 nM
Compound 4 ended at the assay's limit; the forecaster's own chance of this, stated with the estimate: 25%; middle value at least 2.8-fold (0.45 log units) away from the limit.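

In this assay, going by these compounds alone, the earlier steps only swapped or moved a group on a ring attached directly to the carbonyl carbon, whereas this change keeps the 4-chlorophenyl ring and adds a double bond outside it. Replacing 4-chlorophenyl with 2-(4-chlorophenyl)ethenyl gives an at least 2.3-fold higher number from compound 3 to compound 4 (0.36 log units; beyond the scatter), so at this position the change from the directly attached ring is not tolerated as well, and the true size of the step may be larger than this floor. The comparison with the nitro amide gives an at least 1.4-fold higher number from compound 1 to compound 4 (0.15 log units; that floor lies within the scatter), which says little on its own, and the step between the two compounds that both read only as a limit of the assay cannot be read: the limit of > 100000 nM in this assay, at which 2 of the 4 values shown sit.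

The compounds shown leave open whether the weaker reading goes with the double bond itself or with the longer link, a question that the same ring joined through a saturated chain would address. On these data alone, it also remains open how an amine or a carboxylic acid on the ring of the extended group would read in this assay.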